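Shortening One Chain of a Two-Armed Growth Inhibitor

A few compounds are considered here, and "the series" means these few. Any claim that something is new, unique, unknown or untested is made for them only; others in the source may bear on it.

Compound 1, `CC(C)=CC(=O)NC(=N)N`: 92800 nM
Compound 2, `CC(C)=CCC/C(C)=C/CC/C(C)=C/C(=O)NC(=N)NC(=O)/C=C(\C)CC/C=C(\C)CCC=C(C)C`: 5700 nM
Compound 3, `CC(C)=CCC/C(C)=C/C(=O)NC(=N)N`: 17100 nM

Of the compounds shown here, three have been measured in a functional assay on B16-F10 cells (Mus musculus) for inhibition, read by MTT assay, with a stated time of 72 h; on this read-out lower numbers stand for stronger inhibition of growth and higher numbers for weaker inhibition of growth. Compound 2 gives 5700 nM and stands lowest of the three; compound 3 gives 17100 nM and compound 1 gives 92800 nM. Compound 1 and compound 3 differ in one place: hydrogen in place of 3-methylbut-2-en-1-yl on a saturated chain carbon bound to a double-bonded chain carbon. That change makes the step of a 5.4-fold higher number from compound 3 to compound 1 (0.73 log units; beyond the scatter), so cutting the chain down weakens growth inhibition by a modest but real amount. Compound 2 and compound 3 share the same kind of central unit, but how their two cores differ is not broken down here.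

Compound 4, `CC(C)=CCC/C(C)=C/CC/C(C)=C/C(=O)NC(=N)NC(=O)/C=C(\C)CCC=C(C)C`, has not yet been measured in this assay. It is reached from compound 2 by the change (hydrogen in place of 3-methylbut-2-en-1-yl on a saturated chain carbon bound to a double-bonded chain carbon). This is the same change seen from compound 3 to compound 1, at the same kind of place, except that here it is made on one of the two arms of compound 2 while the other arm stays full length. The nearest guide is therefore the step from compound 3 to compound 1, with the caution that compound 2 still keeps one long chain. The step from compound 2 to compound 4 is expected to be a 2.5-fold higher number from compound 2 to compound 4 (0.39 log units; beyond the scatter) in this assay, somewhat smaller than the measured one. Only one of the two arms is trimmed here, and the other remains. Compound 4 is estimated at 14000 nM, plausibly between 6000 nM and 40000 nM.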

Compound 4, concentration for 50% growth inhibition: 18900 nM
The estimate for compound 4 lay 1.4-fold (0.13 log units) below the measured number, within the range that was stated.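

Compound 4 confirms that the trim weakens growth inhibition on this core too: putting hydrogen in place of 3-methylbut-2-en-1-yl on one arm gives, in this assay, a 3.3-fold higher number from compound 2 to compound 4 (0.52 log units; beyond the scatter). This is what medicinal chemists look for when asking whether a change carries over from one core to another, yet two pairs of compounds show only that it acted in the same direction on these two cores, and they cannot establish a rule for other cores or explain why the shorter chain does worse. Measured against the ordinary spread of repeated results, the two steps cannot be told apart in size, so nothing here suggests that the change counts for more on one core than on the other: the same change on two cores in this assay, a 5.4-fold higher number (0.73 log units; beyond the scatter) from compound 3 to compound 1 and a 3.3-fold higher number (0.52 log units; beyond the scatter) from compound 2 to compound 4, 1.6-fold (0.21 log units) apart, within the scatter of two such steps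

The compounds shown leave open what happens when both arms of compound 2 are shortened together, and whether the two losses would simply add up. They also leave open how growth inhibition would respond to a longer chain on either arm, or to a chain carrying a carboxylic acid or an amine.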